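The source may report more compounds than this note shows. Statements on the series, on what has been measured and on what is new or still open speak of the compounds shown alone.

In a functional assay on U-937 cells (Homo sapiens) for antiproliferative activity, read by CCK-8 assay, with a stated time of 72 h (on this read-out lower numbers stand for stronger inhibition and higher numbers for weaker inhibition), compound 1 `Cc1cc(Nc2cc(N3CCN(C)CC3)nc(Nc3ccc([N+](=O)[O-])cc3)n2)n[nH]1` gives 43.3 nM and compound 2 `Cc1cc(Nc2cc(N3CCN(C)CC3)nc(Nc3ccc(Cl)cc3)n2)n[nH]1` gives 55.4 nM while compound 3 `COc1cccc(Nc2nc(Nc3cc(C)[nH]n3)cc(N3CCN(C)CC3)n2)c1` stands highest of the three at 126 nM on this measure. Compound 4 `Cc1cc(Nc2cc(N3CCN(C)CC3)nc(Nc3cccc(Cl)c3)n2)n[nH]1` differs from compound 3 by chloro in place of methoxy on an aromatic carbon, meta to a large group chloro in place of methoxy on an aromatic carbon and has no number yet. The closest evidence is a 2.3-fold higher number from compound 2 to compound 3 (0.36 log units; beyond the scatter) where 3-methoxyphenyl replaces 4-chlorophenyl, so group and place change together. Chloro in place of nitro gave a 1.3-fold higher number from compound 1 to compound 2 (0.11 log units; within the scatter) and 3-methoxyphenyl in place of 4-nitrophenyl gave a 2.9-fold higher number from compound 1 to compound 3 (0.46 log units; beyond the scatter) in the same series. Among the compounds with values here, no measured compound carries 3-chlorophenyl. Read in reverse, a 2.3-fold higher number from compound 2 to compound 3 (0.36 log units; beyond the scatter) suggests that a modest step to a lower number is expected in this assay for this change. For compound 4 the estimate is 60 nM within a range of 25 nM to 130 nM as an expected 2.1-fold lower number from compound 3 to compound 4 (0.32 log units; beyond the scatter) on this read-out.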

Compound 4, half-maximal inhibitory concentration: 21.7 nM
Estimate against measurement, compound 4: 2.8-fold (0.44 log units) above; the whole stated range lies above it.
By their numbers in this assay, from the lowest: compounds 4, 1 and 2 (each within the scatter of the next, the first and the last beyond it); then compound 3.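

In this assay, within the data shown here, chloro in place of methoxy, meta to a large group, gives a 5.8-fold lower number from compound 3 to compound 4 (0.76 log units; beyond the scatter) with nothing else altered, the first reading of this change at a fixed place. Shifting the chloro alone, 3-chlorophenyl in place of 4-chlorophenyl, gives a 2.6-fold lower number from compound 2 to compound 4 (0.41 log units; beyond the scatter) and shows that the place of the chloro counts on its own. Set against 4-nitrophenyl, 3-chlorophenyl gives a 2.0-fold lower number from compound 1 to compound 4 (0.30 log units; within the scatter) and so no order between those two. From the compounds shown here alone, whether an amine or a carboxylic acid at this place would keep the number stays open. No measurement shown accounts for these steps.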